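The compounds below may be only part of what the source reports. "The series", "measured", "known", "first", "only" and "open" are said of these compounds alone.

Compound 1 `CC[C@H](C)C(N)c1cc(C(F)(F)F)ccc1N1CCN(C(=O)CCc2ccc(Cl)cc2Cl)CC1`: in an assay on HEK293 cells for displacement of a labelled ligand from Melanocortin receptor 4 (Homo sapiens) (a lower number here means a stronger inhibitor, a higher number a weaker inhibitor), compound 1 gives 75 nM.
Compound 3 `CCC(C)[C@H](NC[C@H](C)N)c1cc(C(F)(F)F)ccc1N1CCN(C(=O)CCc2ccc(Cl)cc2Cl)CC1`: in this assay compound 3 gives 89 nM.
Compound 2 `CCC(C)[C@H](NCc1ccccc1F)c1cc(C(F)(F)F)ccc1N1CCN(C(=O)CCc2ccc(Cl)cc2Cl)CC1`: in this assay compound 2 reaches only the limit of the assay, > 10000 nM.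

Compound 3 and compound 1 sit together, since a 1.2-fold higher number from compound 1 to compound 3 (0.07 log units; within the scatter). Compound 2 stands apart at a limit, and the step of an at least 110-fold lower number from compound 2 to compound 3 (2.05 log units; beyond the scatter) shows that swapping the group carried by the amine can move the number a long way. Compound 4 `COCCN[C@@H](CC(C)C)c1cc(C(F)(F)F)ccc1N1CCN(C(=O)CCc2ccc(Cl)cc2Cl)CC1` is not yet measured. It differs from compound 3 in one place: 1-((2-methoxyethyl)amino)-3-methylbutyl in place of 1-((2-aminopropyl)amino)-2-methylbutyl on an aromatic carbon. Among the measured compounds shown here, two measured steps bear on this. The small step from compound 1 to compound 3 says that hanging a 2-aminopropyl on the amine changed little; the large step from compound 2 to compound 3 says that what hangs on the amine can matter greatly, with a 1-aminoethyl at one end and a 2-fluorophenyl at the other. A 2-methoxyethyl resembles neither closely, and the chain branching also shifts. A moderate weakening is therefore expected, a 3.4-fold higher number from compound 3 to compound 4 (0.53 log units; beyond the scatter). Compound 4 is estimated at 300 nM, within 80 nM to 2000 nM.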

Compound 4, inhibition constant: 620 nM
For compound 4 the middle estimate is 2.1-fold (0.32 log units) below the measured one, and the stated range covers the measured number.
By their numbers in this assay, from the lowest: compounds 1 and 3 (each within the scatter of the next); then compound 4. At a limit, above all of these: compound 2.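

In this assay, changing the group on this aromatic carbon to 1-((2-methoxyethyl)amino)-3-methylbutyl gives a 7.0-fold higher number from compound 3 to compound 4 (0.84 log units; beyond the scatter) and, measured against the free amine, an 8.3-fold higher number from compound 1 to compound 4 (0.92 log units; beyond the scatter). An open chain with no ring on this amine therefore does not guarantee a number like that of compound 3, and the group it carries can weaken binding by a clear but modest step. Nothing measured here accounts for this weakening.

From the compounds shown here alone, the change from compound 3 to compound 4 swaps a nitrogen for an oxygen and moves the methyl branch in one step, so the part responsible stays open; a 2-aminopropyl on the amine of the 3-methylbutyl chain would separate the two. Also open, going by these compounds, is how a carboxylic acid at the end of the chain on this amine would read.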